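The source may hold more compounds than are shown below. What is called first, only, known or untested is meant among the compounds shown, and "the series" means these compounds.

Working notes on the pancreatic-cell series.

Three compounds have numbers in a functional assay on MIA PaCa-2 cells (Homo sapiens) for inhibition, read by MTT assay, with a stated time of 7 days; a lower number here means a stronger inhibitor, a higher number a weaker inhibitor. Compound 1 `CCOC(=O)[C@H]1CCN(S(=O)(=O)c2ccc(S(=O)(=O)N(CC)CC)cc2)C1` gives 29200 nM. Compound 2 `CCN(CC)S(=O)(=O)c1ccc(S(=O)(=O)N2CCC[C@@H](C(=O)NC3CN(C(=O)NC(C)(C)C)C3)C2)cc1` gives 3400 nM. Compound 3 `CC(C)c1noc(N2CCN(C(=O)[C@@H]3CCCN(S(=O)(=O)c4ccc(S(=O)(=O)C5CCC5)cc4)C3)CC2)n1` gives 70 nM, the lowest of the three numbers; its gaps to compound 2 and to compound 1 are both well beyond the scatter, so compound 3 stands as the strongest inhibitor among those measured here. Within the data shown here, no pair among the measured compounds differs in a single place, so no step has been isolated yet.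

Compound 4 `CCN(CC)C(=O)c1ccc(S(=O)(=O)N2CCC[C@@H](C(=O)N3CCN(c4nc(C(C)C)no4)CC3)C2)cc1` is the next candidate and differs from compound 3 in one place: diethylcarbamoyl in place of cyclobutylsulfonyl on an aromatic carbon. Among the measured compounds shown here, no earlier pair shows what this exchange does on this scaffold, and compound 1 and compound 2, which carry a different group at that ring position together with other changes, give no clean comparison. A modest loss is expected, with the step from compound 3 to compound 4 estimated at a 2.6-fold higher number from compound 3 to compound 4 (0.41 log units; beyond the scatter) in this assay. Compound 4 is therefore estimated at 180 nM, with a range from 40 nM to 800 nM.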

Compound 4, half-maximal inhibitory concentration: 100 nM
Compound 4: the middle estimate sits 1.8-fold (0.26 log units) above what was measured, and the stated range covers the measured number.
By their numbers in this assay, from the lowest: compounds 3 and 4 (each within the scatter of the next); then compound 2; then compound 1.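

In this assay, diethylcarbamoyl in place of cyclobutylsulfonyl on this aromatic carbon, para to a large group, gives a 1.4-fold higher number from compound 3 to compound 4 (0.15 log units; within the scatter) and leaves compound 3 and compound 4 indistinguishable. Among these compounds, this is the first clean reading at this position: it tolerates the loss of the four-membered ring and of the sulfonyl group without a change that can be separated from the scatter, which the earlier compounds, with their several simultaneous differences, could not show. No measurement at hand accounts for the two groups reading alike.

The compounds shown leave open whether a carboxylic acid or a primary amine on this aromatic carbon would also read alike. On these data alone, it also remains open whether this exchange gives the same result when another part of the shared core is changed.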